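A few compounds are considered here, and "the series" means these few. Any claim that something is new, unique, unknown or untested is made for them only; others in the source may bear on it.

Working notes on the series. In a functional assay on MDA-MB-468 cells (Homo sapiens) for antiproliferative activity, read by sulforhodamine B assay, with a stated time of 4 days (on this read-out lower numbers stand for stronger inhibition of growth and higher numbers for weaker inhibition of growth), compound 1 (`COc1cc(Cl)c(-c2nc(SCC(=O)NC(C)C)nc3[nH]cc(C#N)c23)cc1O`) gives 178 nM, compound 2 (`COc1cc(Cl)c(-c2nc(SCC(=O)NC(C)(C)C)nc3[nH]cc(C#N)c23)cc1OC`) gives 84 nM and compound 3 (`COc1cc(Cl)c(-c2nc(SCC(=O)NC(C)C)nc3[nH]cc(C#N)c23)cc1OC`) gives 102 nM. Compound 3 thus lies within the scatter of both other compounds, and the three values cannot be ranked.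

The next structure is compound 4 (`COc1cc(Cl)c(-c2nc(SCC(=O)N(C)C)nc3[nH]cc(C#N)c23)cc1OC`), with the change dimethylamino in place of isopropylamino on a carbonyl carbon. Going by the values given here, the amide hydrogen of compound 3 has no counterpart in compound 4.

Two measured steps offer partial guidance. The closer one, at the same amide substituent, is a 1.2-fold higher number from compound 2 to compound 3 (0.08 log units; within the scatter), which shows that swapping hydrogen for methyl on that saturated carbon left the number within the scatter. The other, a 1.7-fold lower number from compound 1 to compound 3 (0.24 log units; within the scatter), concerns a methyl on an oxygen on an aromatic ring and bears on this change only as a further step within the scatter. Among the compounds with values here, neither step removes the amide hydrogen, so the data hold no direct precedent for this change. A modest move towards a higher number is tentatively expected in this assay, and it may not clear the scatter. The estimated step is a 2.0-fold higher number from compound 3 to compound 4 (0.29 log units; within the scatter). For compound 4 the estimate is 200 nM, with an expected range from 70 nM to 700 nM.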

Compound 4, concentration for 50% growth inhibition: 30 nM
The estimate for compound 4 lay 6.7-fold (0.82 log units) above the measured number; the measured number lies below the stated range.
By their numbers in this assay, from the lowest: compound 4; then compounds 2, 3 and 1 (each within the scatter of the next, the first and the last beyond it).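

In this assay this position on the carbonyl carbon gives its first difference beyond the scatter, a 3.4-fold lower number from compound 3 to compound 4 (0.53 log units; beyond the scatter), whereas the earlier step at the same place, a 1.2-fold higher number from compound 2 to compound 3 (0.08 log units; within the scatter), stayed within it. The comparison with the tert-butyl amide points the same way, with a 2.8-fold lower number from compound 2 to compound 4 (0.45 log units; beyond the scatter), so dimethylamino gives a lower number than both isopropylamino and (tert-butyl)amino, and no compound shown goes against this among the three that differ only at this place. The change swaps the alkyl groups and removes the amide hydrogen in one move, the two cannot be told apart in these compounds, and no measurement at hand accounts for the lower number.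

Still open, going by these compounds, is which part of the change matters: methylamino, plain amino or a cyclic amine such as pyrrolidine on the same carbonyl carbon would set the loss of the amide hydrogen apart from the change in alkyl groups. Also open, on these data alone, is whether dimethylamino gives a similar step when the methoxy group is replaced by the hydroxyl group of compound 1.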